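The source may hold more compounds than are shown below. What is called first, only, known or untested is meant among the compounds shown, and "the series" means these compounds.

Measured in a functional assay on the whole organism with Mus musculus as the target, with a stated time of 0.5 h; on this read-out higher numbers stand for an effect only at larger amounts of compound and lower numbers for an effect already at smaller amounts:
- Compound 1 (`CC[C@]1(c2ccccc2)OC(=O)NC1=O`): 108 mg/kg
- Compound 2 (`CC[C@]1(c2ccccc2)OC(=O)N(C)C1=O`): 69 mg/kg

Among the measured compounds shown here, compound 2 stands within the scatter of compound 1, the only other measured compound, as the step shows: a 1.6-fold lower number from compound 1 to compound 2 (0.19 log units; within the scatter). Compound 3 (`CC[C@@]1(c2ccccc2)OC(=O)N(C)C1=O`) differs from compound 2 as follows: the two compounds have the same atoms and bonds and differ only in configuration as drawn: 1 of 1 stereo elements differ; a stereocentre at a saturated ring carbon is drawn R in compound 2 and S in compound 3. For the measured compounds named here, that single measured step concerns a methyl in place of hydrogen on an amide-type nitrogen in a ring, so no measured step tests configuration. No shift beyond the scatter is therefore expected in this assay, although this expectation is weakly supported. The expected step is a 1.1-fold higher number from compound 2 to compound 3 (0.04 log units; within the scatter). For compound 3 the estimated value is 75 mg/kg, with an expected range of 35 mg/kg to 160 mg/kg.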

Compound 3, dose for half-maximal effect: 64 mg/kg
Estimate against measurement, compound 3: 1.2-fold (0.07 log units) above, within the range that was stated.
By their numbers in this assay, from the lowest: compounds 3, 2 and 1 (each within the scatter of the next).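

In this assay, changing the configuration drawn at the saturated ring carbon gives a 1.1-fold lower number from compound 2 to compound 3 (0.03 log units; within the scatter), the first measured test of this stereocentre, as the earlier step concerned only the amide-type nitrogen in a ring. With the methyl on that nitrogen, this read-out does not separate the two drawn configurations. The comparison isolates configuration alone: the fact that compounds 2 and 3 differ only in the configuration as drawn

Compound 1, with the hydrogen on that nitrogen, is shown in one configuration only, and whether configuration matters there stays open. Also open, from the compounds shown here alone, is how this assay responds to a longer chain or an amine in place of the methyl.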